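A few compounds are considered here, and "the series" means these few. Any claim that something is new, unique, unknown or untested is made for them only; others in the source may bear on it.

Compound 2 (`COc1ccc(NC(=O)C(=O)c2cn(CCC(=O)O)c3ccccc23)cn1`) is measured in a physicochemical assay for solubility, in phosphate buffer, at pH 7.4 (on this read-out higher numbers stand for higher solubility and lower numbers for lower solubility), as is its relative compound 1 (`COc1ccc(NC(=O)C(=O)c2cn(C(C)(C)COCC(=O)O)c3ccccc23)cn1`). In this assay compound 2 gives <= 200000 nM, which is a limit and not a number. Compound 1 gives <= 200000 nM, which is likewise a limit. Both results sit at the same point, (the limit of <= 200000 nM in this assay, at which 2 of the 2 values shown sit), so the position of compound 2 is bounded but not fixed.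

Compound 3 (`COCC(C)(C)n1cc(C(=O)C(=O)Nc2ccc(OC)nc2)c2ccccc21`) carries 1-(methoxymethyl)-1-methylethyl in place of 2-carboxyethyl on an aromatic nitrogen. Among the measured compounds shown here, the only measured step that bears on this change is a step that the two limits leave unreadable from compound 1 to compound 2. Its size cannot be read, so it offers no measured guide to how far compound 3 may move. Any expectation therefore rests on the structural change alone and carries wide uncertainty. In this assay the expected direction is downward, with an estimated step that the limit leaves unreadable from compound 2 to compound 3. Compound 3 is estimated at 8000 nM, with an expected range from 1000 nM to 60000 nM.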

Compound 3, solubility: 10000 nM
Beside the measured number, compound 3's estimate is 1.3-fold (0.10 log units) below it, within the range that was stated.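

The steps from compound 2 to compound 3 and from compound 1 to compound 3 cannot be read, since in this assay compound 1 and compound 2 each give a limit and not a number: the limit of <= 200000 nM in this assay, at which 2 of the 3 values shown sit.

The compounds shown leave open how far the true values of compound 1 and compound 2 lie from that of compound 3.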